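A few compounds are considered here, and "the series" means these few. Any claim that something is new, unique, unknown or untested is made for them only; others in the source may bear on it.

In a functional assay on K562 cells (Homo sapiens), with a stated time of 96 h (on this read-out higher numbers stand for weaker inhibition of growth and lower numbers for stronger inhibition of growth), the three measured compounds give the following numbers:

compound 1 `COc1ccc(NS(=O)(=O)c2cc3cc(Cl)ccc3oc2=O)cc1` gives 23000 nM
compound 2 `CCOc1cccc2cc(S(=O)(=O)Nc3ccc(OC)cc3)c(=O)oc12` gives 48000 nM
compound 3 `COc1ccc(NS(=O)(=O)c2cc3cc(Cl)ccc3oc2=O)cc1O` gives 51000 nM

All three are weak growth inhibitors. Compound 2 stands second highest of the three numbers in this assay; its nearest neighbour is compound 3, whose value lies within the usual scatter of it, and its furthest is compound 1, which sits beyond the scatter at the lower end. Going by the values given here, the only single-point step among the measured compounds is a 2.2-fold higher number from compound 1 to compound 3 (0.35 log units; beyond the scatter), a modest shift that comes from a hydroxy in place of hydrogen on an aromatic carbon.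

Compound 4 `CCOc1cccc2cc(S(=O)(=O)Nc3ccc(Br)cc3)c(=O)oc12` differs from compound 2 in one place: bromo in place of methoxy on an aromatic carbon. No measured step touches this kind of exchange, so there is nothing among the shown compounds that directly predicts the direction. Given that the ring carrying the 4-methoxyphenyl group is untouched elsewhere, and that the measured steps stay small, the change from compound 2 to compound 4 is expected to be a 1.2-fold lower number from compound 2 to compound 4 (0.08 log units; within the scatter), that is, no step beyond the scatter. Compound 4 is therefore estimated at 40000 nM in this assay, with a plausible range from 15000 nM to 100000 nM.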

Compound 4, concentration for 50% growth inhibition: 58000 nM
Beside the measured number, compound 4's estimate is 1.5-fold (0.16 log units) below it; measured number inside the range.
By their numbers in this assay, from the lowest: compound 1; then compounds 2, 3 and 4 (each within the scatter of the next).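

In this assay, the step of a 1.2-fold higher number from compound 2 to compound 4 (0.08 log units; within the scatter) stays within the scatter, so at this place on the six-membered aromatic ring of carbon only, para to a large group, 4-methoxyphenyl and 4-bromophenyl cannot be told apart. Going by these compounds alone, this is the first reading at this position, as the one earlier step concerned a different change, hydroxy in place of hydrogen on the core of compound 1. It shows that methoxy, with its one hydrogen-bond acceptor, can give way to bromo, with none, without a change in growth inhibition that can be separated from the scatter, and no data are available here to explain this result.

On these data alone, only these two groups are compared at this place, so it remains open whether an amine, a carboxylic acid or a longer chain there would shift the number beyond the scatter. As far as these compounds go, it also remains open whether the exchange of methoxy for bromo would read the same way on the core of compound 1 as it does on the core of compound 2.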